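Swapping 3-methoxyphenyl for 3,5-dimethylphenyl on compound 1

The source may report more compounds than this note shows. Statements on the series, on what has been measured and on what is new or still open speak of the compounds shown alone.

Compound 1 `COC1=C(C)C(=O)/C(=C(O)/C=C/c2cccc(OC)c2)C(=O)C1(C)C`: 2.8 ug/mL
Compound 2 `COC1=C(C)C(=O)/C(=C(O)/C=C/c2ccc(F)cc2)C(=O)C1(C)C`: 3.3 ug/mL
Compound 3 `CCc1ccc(/C=C/C(O)=C2/C(=O)C(C)=C(OC)C(C)(C)C2=O)cc1`: 6.1 ug/mL

These values come from a functional assay on A549 cells (Homo sapiens) for cytotoxicity; on this read-out lower numbers stand for an effect already at smaller amounts and higher numbers for an effect only at larger amounts of compound. Compound 1 and compound 2 together form the low end of the three numbers, with a 1.2-fold higher number from compound 1 to compound 2 (0.07 log units; within the scatter). Compound 3 stands apart from compound 1 only modestly, with a 2.2-fold higher number from compound 1 to compound 3 (0.34 log units; beyond the scatter), while a 1.8-fold higher number from compound 2 to compound 3 (0.27 log units; within the scatter).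

Compound 4 `COC1=C(C)C(=O)/C(=C(O)/C=C/c2cc(C)cc(C)c2)C(=O)C1(C)C` keeps the core of compound 1 and carries 3,5-dimethylphenyl in place of 3-methoxyphenyl on a double-bonded chain carbon bound to a double-bonded chain carbon. Two measured steps replace the same group at the same place. Among the compounds with values here, the replacement in compound 2 gave a 1.2-fold higher number from compound 1 to compound 2 (0.07 log units; within the scatter), and the one in compound 3, which also brings a carbon-only substituent, gave a 2.2-fold higher number from compound 1 to compound 3 (0.34 log units; beyond the scatter). Within the data shown here, no measured compound carries 3,5-dimethylphenyl itself. In this assay a small upward step is therefore expected, probably not clearly beyond the scatter. The estimated step is a 1.5-fold higher number from compound 1 to compound 4 (0.19 log units; within the scatter). For compound 4 the expected value is 4.3 ug/mL, with an estimated range from 2.1 ug/mL to 8.8 ug/mL.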

Compound 4, concentration for half-maximal effect: 4.3 ug/mL
Estimate against measurement, compound 4: no gap at the digits printed; measured number inside the range.
By their numbers in this assay, from the lowest: compounds 1, 2, 4 and 3 (each within the scatter of the next, the first and the last beyond it).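

In this assay, 3,5-dimethylphenyl has no hydrogen-bond acceptor where 3-methoxyphenyl has 1, yet this exchange leaves the number within the scatter (a 1.5-fold higher number from compound 1 to compound 4 (0.19 log units; within the scatter)). Compound 4 is also within the scatter of the two other replacements (a 1.3-fold higher number from compound 2 to compound 4 (0.11 log units; within the scatter); a 1.4-fold lower number from compound 3 to compound 4 (0.15 log units; within the scatter)), so at this place on a double-bonded chain carbon, the new aryl group does not separate from the three earlier ones. Nothing given here bears on what lies behind these steps.

On these data alone, what a phenyl ring carrying an amine or a carboxylic acid would give at this place remains open. So does the outcome with a longer chain in place of these aryl groups.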